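The compounds below may be only part of what the source reports. "The series", "measured", "known", "first", "only" and "open" are said of these compounds alone.

Measured so far:
compound 1, `CCN(CC)CN1C(=O)/C(=N/NC(=S)Nc2ccccc2)c2cc(Cl)ccc21`: 34000 nM
compound 2, `CCN(CC)CN1C(=O)/C(=N/NC(=S)Nc2ccc(OC)cc2)c2cc(Cl)ccc21`: 9200 nM

In a functional assay on HeLa cells (Homo sapiens) for inhibition, read by cell counting, with a stated time of 96 h (on this read-out lower numbers stand for stronger inhibition and higher numbers for weaker inhibition), compound 2 gives the lowest number of the two; its nearest neighbour is compound 1, and the step of a 3.7-fold lower number from compound 1 to compound 2 (0.57 log units; beyond the scatter) lies beyond the scatter. Compound 3, `CCN(CC)CN1C(=O)/C(=N/NC(=S)Nc2ccc(C)cc2)c2cc(Cl)ccc21`, differs from compound 2 by methyl in place of methoxy on an aromatic carbon. For the measured compounds named here, no measured step swaps methyl for methoxy at this place; the only step that bears on it is a 3.7-fold lower number from compound 1 to compound 2 (0.57 log units; beyond the scatter), which shows that putting a group at this place moves the read-out by a modest amount. As methyl is neither the hydrogen of compound 1 nor the methoxy of compound 2, a number between those two is expected, somewhat closer to compound 2. The step of a 1.6-fold higher number from compound 2 to compound 3 (0.21 log units; within the scatter) is therefore expected to be small, toward a higher number, likely within the scatter. For compound 3 the estimate is 15000 nM, with a range from 5000 nM to 45000 nM.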

Compound 3, half-maximal inhibitory concentration: 8600 nM
For compound 3 the middle estimate is 1.7-fold (0.24 log units) above the measured one; low and high end bracket the measured number.
By their numbers in this assay, from the lowest: compounds 3 and 2 (each within the scatter of the next); then compound 1.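

Replacing methoxy with methyl at this place in this assay gives a 1.1-fold lower number from compound 2 to compound 3 (0.03 log units; within the scatter) and so leaves the read-out within the scatter. Set against the hydrogen of compound 1, methyl gives a 4.0-fold lower number from compound 1 to compound 3 (0.60 log units; beyond the scatter) and so matches the earlier step seen with methoxy, which means that this step does not require the oxygen or the hydrogen-bond acceptor that methoxy carries and methyl lacks. No measurement at hand explains why these two groups behave alike here.

With only hydrogen, methyl and methoxy shown at this place, it stays open whether almost any added group would serve, or whether fluorine, an amine, a carboxylic acid or a longer chain such as butyl would give a clearly different number. As far as these compounds go, it also stays open whether the same steps would appear with a change elsewhere on the shared core.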